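The compounds below may be only part of what the source reports. "The series", "measured", "known", "first", "only" and "open" are said of these compounds alone.

Measured in a functional assay on OVCAR-8 cells (Homo sapiens); on this read-out higher numbers stand for weaker inhibition of growth and lower numbers for stronger inhibition of growth:
- compound 1 `O=S(=O)(/C=C/c1ccccc1)Cc1ccc(Nc2ncnc3ccccc23)cc1`: > 100000 nM, a limit
- compound 2 `N#Cc1ccc(/C=C/S(=O)(=O)Cc2ccc(Nc3ncnc4ccccc34)cc2)cc1`: > 100000 nM, a limit
- compound 3 `O=S(=O)(/C=C/c1ccc(Cl)cc1Cl)Cc1ccc(Nc2ncnc3ccccc23)cc1`: 4000 nM

Among the compounds with values here, compound 3 is the only compound with a number, 4000 nM. The other two values sit at a limit: the limit of > 100000 nM in this assay, at which 2 of the 3 values shown sit.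

Compound 4 `O=S(=O)(/C=C/c1ccc(C(F)(F)F)cc1F)Cc1ccc(Nc2ncnc3ccccc23)cc1` differs from compound 3 as follows: 2-fluoro-4-(trifluoromethyl)phenyl in place of 2,4-dichlorophenyl on a double-bonded chain carbon bound to a double-bonded chain carbon.

Within the data shown here, two measured steps concern this same place: an at least 25-fold lower number from compound 1 to compound 3 (1.39 log units; beyond the scatter) and an at least 25-fold lower number from compound 2 to compound 3 (1.39 log units; beyond the scatter). Both are large. Compound 2 also carries a substituted phenyl, and it gives > 100000 nM, a limit. Among the measured compounds shown here, no measured step starts from the 2,4-dichlorophenyl, so the risk of a large loss stays open.

The expected change is no step beyond the scatter, a 1.5-fold higher number from compound 3 to compound 4 (0.18 log units; within the scatter), leaning slightly towards a higher number.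

For compound 4 the estimate is 6000 nM, with an expected range of 1200 nM to 50000 nM.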

Compound 4, concentration for 50% growth inhibition: 100000 nM
Compound 4: middle estimate off by 17-fold (1.22 log units), on the low side; the measured number lies above the stated range.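

In this assay, the change from 2,4-dichlorophenyl to 2-fluoro-4-(trifluoromethyl)phenyl gives a 25-fold higher number from compound 3 to compound 4 (1.40 log units; beyond the scatter), so the gain at this place does not extend to every halogen-bearing phenyl. The sizes of the two other steps, a number no higher from compound 1 to compound 4 (the limit leaves the size open) and a number no higher from compound 2 to compound 4 (the limit leaves the size open), cannot be read, since both start from a limit: the limit of > 100000 nM in this assay, at which 2 of the 4 values shown sit.

Open, as far as these compounds go, is whether a 4-chlorophenyl or a 2-chlorophenyl alone would keep the number of compound 3. Also open, from the compounds shown here alone, is how a dimethylamino group on this phenyl would read.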